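A few compounds are considered here, and "the series" means these few. Any claim that something is new, unique, unknown or untested is made for them only; others in the source may bear on it.

Of the compounds shown here, three have been tested in a physicochemical assay for solubility, in phosphate buffer, measured as kinetic solubility, at pH 7.4 (on this read-out lower numbers stand for lower solubility and higher numbers for higher solubility), and none of them has yet given a plain number. Compound 2 `Cc1oc(-c2c(Cl)cccc2Br)nc1CN1CCC(C(=O)NCCCN2C[C@H](C)C[C@H](C)C2)CC1` reads > 83 ug/mL, which is a limit of the assay and not a number. Compound 1 `Cc1oc(-c2ccccc2Cl)nc1CN1CCC(C(=O)NCCCN2C[C@H](C)C[C@H](C)C2)CC1` reads > 72 ug/mL, also a limit. Compound 3 `Cc1cccc(Cl)c1-c1nc(CN2CCC(C(=O)NCCCN3CCC(C(C)C)CC3)CC2)c(C)o1` reads > 76 ug/mL, again a limit. Compound 2 can therefore be placed only by its limit, not ranked against the other two.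

Compound 4 `CCc1ccccc1-c1nc(CN2CCC(C(=O)NCCCN3C[C@H](C)C[C@H](C)C3)CC2)c(C)o1` has not yet been measured in this assay. It differs from compound 2 in a single place: 2-ethylphenyl in place of 2-bromo-6-chlorophenyl on an aromatic carbon. The change lies on an aromatic carbon of a five-membered aromatic ring with 1 nitrogen and 1 oxygen.

Among the compounds with values here, only one measured step changes this group: a step that the two limits leave unreadable from compound 1 to compound 2. Both of its ends are limits, so it gives no size to carry over. With no readable step to suggest otherwise, an at least 1.1-fold lower number from compound 2 to compound 4 (0.06 log units; that floor lies within the scatter) is expected to stay within the usual scatter. For compound 4 the estimated value is 72 ug/mL, with an expected range of 45 ug/mL to 90 ug/mL.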

Compound 4, solubility: 55.9 ug/mL
Compound 4: middle estimate off by 1.3-fold (0.11 log units), on the high side, within the range that was stated.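

Within the data shown here, compound 4 gives the first plain number in this assay, so this place on the core now has one compound with a readable value. Putting 2-ethylphenyl in place of 2-bromo-6-chlorophenyl gives an at least 1.4-fold lower number from compound 2 to compound 4 (0.17 log units; that floor lies within the scatter), and putting ethyl in place of chloro gives an at least 1.2-fold lower number from compound 1 to compound 4 (0.10 log units; that floor lies within the scatter). Each step starts from a limit of the assay and not a number, so its true size may exceed its floor, and compound 2 shows this kind of start: the limit of > 83 ug/mL in this assay, at which 1 of the 4 values shown sits.

Going by these compounds, the true size of both steps stays open, and the step between compound 1 and compound 2 cannot be read. Also open, on these data alone, is how this assay would respond if an amine or a carboxylic acid stood in place of the ethyl on this aromatic ring.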